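Removing the Chloro Group from Compound 2

This account rests on a few compounds, and the source may have more. Where it says the series, first, only, none or still open, it means among the compounds named here.

- compound 1 `COc1ccc2cc(C(C)c3nnc4n3N=C(c3ccc(Br)cc3)CS4)ccc2c1`: 11700 nM
- compound 2 `CC(C)Cc1ccc(C(C)c2nnc3n2N=C(c2ccc(Cl)cc2)CS3)cc1`: 6700 nM
- compound 3 `COc1ccc2cc(C(C)c3nnc4n3N=C(c3ccc(Cl)cc3Cl)CS4)ccc2c1`: 14000 nM

All three values come from a functional assay on HCT-116 cells (Homo sapiens) for inhibition, read by sulforhodamine B assay, with a stated time of 72 h; a higher number here means a weaker inhibitor, a lower number a stronger inhibitor. Compound 2 gives 6700 nM, which lies within the usual scatter of compound 1 at 11700 nM. Compound 3 at 14000 nM reads higher than compound 2, only just beyond the scatter.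

The next compound to be tested is compound 4 `CC(C)Cc1ccc(C(C)c2nnc3n2N=C(c2ccccc2)CS3)cc1`. It differs from compound 2 by one small edit: hydrogen in place of chloro on an aromatic carbon. Hydrogen takes the place of chloro on an aromatic carbon, turning 4-chlorophenyl into phenyl.

Among the compounds with values here, one measured step touches this same part of the structure. Placing 2,4-dichlorophenyl in the spot held by 4-bromophenyl gave a 1.2-fold higher number from compound 1 to compound 3 (0.08 log units; within the scatter). That pair also differs from compound 2 elsewhere, and every measured compound still carries halogen on this ring. Within the data shown here, the data therefore offer only an indirect guide, and no measured step shows what happens when the halogen is removed entirely.

On this limited evidence, no change beyond the scatter is expected, and the expected step is a 1.3-fold higher number from compound 2 to compound 4 (0.10 log units; within the scatter). The estimate for compound 4 is 8500 nM, with an expected range from 4000 nM to 18000 nM.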

Compound 4, half-maximal inhibitory concentration: 7600 nM
Estimate against measurement, compound 4: 1.1-fold (0.05 log units) above; the range from low to high includes it.
By their numbers in this assay, from the lowest: compounds 2, 4, 1 and 3 (each within the scatter of the next, the first and the last beyond it).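

Taking the chloro group off, which turns 4-chlorophenyl into phenyl, gives a 1.1-fold higher number from compound 2 to compound 4 (0.05 log units; within the scatter) in this assay, so in this pair the chlorine atom makes no difference that can be told from the usual spread of repeat measurements. Within the data shown here, the earlier compounds could not show this: all of them carried halogen on this ring, and the one measured step there only exchanged 4-bromophenyl for 2,4-dichlorophenyl, while this step is the first to compare a halogen with plain hydrogen at this aromatic carbon. No measurement is available that would explain why the two compounds read alike.

Still open, as far as these compounds go, is whether a group of a different kind at this place on the phenyl ring, such as an amine, a carboxylic acid or a longer chain, would move the number beyond the scatter from that of compound 4. Among these compounds, it is also open whether removing the halogen would read the same in a compound carrying the other side group found in compound 1 and compound 3, instead of the one shared by compound 2 and compound 4.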